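Removing the Methyl from the Ether Oxygen of Compound 3

A few compounds are considered here, and "the series" means these few. Any claim that something is new, unique, unknown or untested is made for them only; others in the source may bear on it.

Three compounds sharing a common core were examined in a functional assay on SN12C cells (Homo sapiens) for inhibition, read by sulforhodamine B assay, with a stated time of 48 h; a higher number here means that more compound is tolerated, a lower number that less compound is tolerated. Compound 1 `O=C(Nc1cccc(-n2cc(-c3ccncc3)c(-c3ccc(Cl)c(O)c3)n2)c1)Nc1cccc(C(F)(F)F)c1` gives only a limit of the assay, > 32500 nM. Compound 2 `COc1cc(-c2nn(-c3cccc(NC(=O)c4cccc(C(F)(F)F)c4)c3)cc2-c2ccncc2)ccc1Cl` likewise returns a limit, > 50000 nM. Compound 3 `COc1cc(-c2nn(-c3cccc(NC(=O)Nc4ccc(Cl)c(Cl)c4)c3)cc2-c2ccncc2)ccc1Cl` also sits at a limit, with > 50000 nM in this assay. Going by the values given here, the only single-point step among the measured compounds, a step that the two limits leave unreadable from compound 2 to compound 3, puts (3,4-dichlorophenyl)amino in place of 3-(trifluoromethyl)phenyl on a carbonyl carbon, and its size cannot be read: both ends are limits, as the limit of > 50000 nM in this assay, at which 2 of the 3 values shown sit, records. Among the compounds with values here, the remaining value, described by the limit of > 32500 nM in this assay, at which 1 of the 3 values shown sits, is a limit as well, so no compound in the set offers a numeric anchor, and compound 3 stands at the edge of what this assay reports.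

Compound 4 `O=C(Nc1cccc(-n2cc(-c3ccncc3)c(-c3ccc(Cl)c(O)c3)n2)c1)Nc1ccc(Cl)c(Cl)c1` differs from compound 3 by hydrogen in place of methyl on an oxygen on an aromatic ring, which turns methoxy into hydroxy and 4-chloro-3-methoxyphenyl into 4-chloro-3-hydroxyphenyl. Within the data shown here, no measured step follows this exact change. Compound 1 already carries the hydroxy group and gives a limit, and compound 3 gives a limit too. The step of a number no higher from compound 3 to compound 4 (the limit leaves the size open) is therefore expected to stay within the scatter. Compound 4 is estimated at 50000 nM, in the range 20000 nM to 150000 nM, most probably reported once more as a limit.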

Compound 4, concentration lethal to 50% of the cells: > 32500 nM
Compound 4 was reported as a limit; the forecaster's own chance of this, stated with the estimate: 75%; the middle value lies beyond the limit too.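

In this assay compound 4 gives > 32500 nM, which is a limit of the assay. Its steps from compound 3 and from compound 1 have limits at both ends, so neither can be read. The compounds shown leave open whether methoxy and hydroxy, or 3,4-dichlorophenyl and 3-(trifluoromethyl)phenyl, differ at all in this assay.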